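This account rests on a few compounds, and the source may have more. Where it says the series, first, only, none or still open, it means among the compounds named here.

Compound 1 `CC(=O)Nc1ccn([C@@H]2CO[C@H](CO)O2)c(=O)n1`: 10700 nM. Compound 2 `CCCCCCC(=O)Nc1ccn([C@@H]2CO[C@H](CO)O2)c(=O)n1`: 2400 nM. Compound 3 `O=C(Nc1ccn([C@@H]2CO[C@H](CO)O2)c(=O)n1)C1CC1`: 22000 nM.

All three were tested in a functional assay on SW1573 cells (Homo sapiens) for cytotoxicity, read by sulforhodamine B assay, with a stated time of 72 h; a higher number here means a weaker inhibitor, a lower number a stronger inhibitor. Compound 3 gives the highest of the three numbers, with a 2.1-fold higher number from compound 1 to compound 3 (0.31 log units; beyond the scatter) and a 9.2-fold higher number from compound 2 to compound 3 (0.96 log units; beyond the scatter). Compound 4 `O=C(Nc1ccn([C@@H]2CO[C@H](CO)O2)c(=O)n1)C1CCCC1` is not yet measured; it differs from compound 3 by cyclopentyl in place of cyclopropyl on a carbonyl carbon. Going by the values given here, the steps that bear on this change sit on the same carbonyl carbon: a 4.5-fold lower number from compound 1 to compound 2 (0.65 log units; beyond the scatter) and a 9.2-fold higher number from compound 2 to compound 3 (0.96 log units; beyond the scatter) both pair a larger group with a lower number, although a 2.1-fold higher number from compound 1 to compound 3 (0.31 log units; beyond the scatter) runs the other way. On balance compound 4 is expected to give a lower number than compound 3, the estimated step being a 3.7-fold lower number from compound 3 to compound 4 (0.56 log units; beyond the scatter). Compound 4 is therefore estimated at 6000 nM, with a range from 2000 nM to 18000 nM.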

Compound 4, half-maximal inhibitory concentration: 8800 nM
Compound 4: the middle estimate sits 1.5-fold (0.17 log units) below what was measured; the measured number falls inside the stated range.
By their numbers in this assay, from the lowest: compound 2; then compounds 4 and 1 (each within the scatter of the next); then compound 3.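

In this assay, a ring change alone on this carbonyl carbon matters: cyclopentyl in place of cyclopropyl gives a 2.5-fold lower number from compound 3 to compound 4 (0.40 log units; beyond the scatter). Even so, cyclopentyl cannot be told apart from methyl, with a 1.2-fold lower number from compound 1 to compound 4 (0.08 log units; within the scatter), and it falls short of hexyl, with a 3.7-fold higher number from compound 2 to compound 4 (0.56 log units; beyond the scatter), so a larger group does not by itself bring a lower number. Nothing measured here explains these differences. The compounds shown leave open how a cyclohexyl ring, a phenyl ring or a chain longer than hexyl would read on this carbonyl carbon.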